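From Butoxymethyl to Fluoromethyl on a Shared Core

The source may report more compounds than this note shows. Statements on the series, on what has been measured and on what is new or still open speak of the compounds shown alone.

Measured in a functional assay on HFF cells (Homo sapiens) for cytotoxicity; a lower number here means a stronger inhibitor, a higher number a weaker inhibitor:
- compound 1 `CCOC[C@H]1OC(n2c(Cl)nc3cc(Cl)c(Cl)cc32)[C@H](O)[C@@H]1O`: 26000 nM
- compound 2 `CCCCOC[C@H]1OC(n2c(Cl)nc3cc(Cl)c(Cl)cc32)[C@H](O)[C@@H]1O`: 32000 nM

In this assay, compound 2 gives 32000 nM, a value within the scatter of compound 1 at 26000 nM. Compound 3 `O[C@@H]1[C@@H](CF)OC(n2c(Cl)nc3cc(Cl)c(Cl)cc32)[C@@H]1O` has not yet been measured. It departs from compound 2 as follows: fluoro in place of butoxy on a saturated chain carbon bound to a saturated ring carbon. This places fluoro in place of butoxy on a saturated chain carbon bound to a saturated ring carbon. Within the data shown here, only one measured step bears on this change, and it is an indirect guide: a 1.2-fold higher number from compound 1 to compound 2 (0.09 log units; within the scatter). Among the measured compounds shown here, that step alters the chain while keeping its oxygen, and no measured compound carries fluoro. No change beyond the scatter is therefore expected, though with wide uncertainty. The estimated step is a 1.1-fold lower number from compound 2 to compound 3 (0.03 log units; within the scatter). Compound 3 is expected to give 30000 nM, with an estimated range of 10000 nM to 90000 nM.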

Compound 3, half-maximal inhibitory concentration: 32000 nM
Compound 3: the middle estimate sits 1.1-fold (0.03 log units) below what was measured, within the range that was stated.
By their numbers in this assay, from the lowest: compounds 1, 2 and 3 (each within the scatter of the next).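

Exchanging butoxy for fluoro on a saturated chain carbon bound to a saturated ring carbon, read in this assay, gives no change at the digits printed from compound 2 to compound 3 (within the scatter), and exchanging ethoxy for fluoro gives a 1.2-fold higher number from compound 1 to compound 3 (0.09 log units; within the scatter). The earlier pair had altered only the chain and kept its oxygen, whereas compound 3 shows that removing both the chain and its oxygen, with fluoro in their place, still yields no step beyond the scatter at this position. No supporting measurement is available to explain this result.

The compounds shown leave open whether a hydroxyl, an amine or a carboxylic acid at this position, or a chain longer than butoxy, would also remain within the scatter of these values. They also do not show whether any group here can shift the reading in this assay beyond the scatter.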